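The compounds below may be only part of what the source reports. "The series", "measured", "known", "first", "only" and "open" are said of these compounds alone.

Compound 1 `COc1cccnc1Nc1cc2[nH]c(-c3cccc(C(F)(F)F)c3)nc2cn1` is one of three related compounds tested in a physicochemical assay for solubility, using the shake flask method, measured as kinetic solubility, with a stated time of 20 h, at pH 2 (on this read-out higher numbers stand for higher solubility and lower numbers for lower solubility), where compound 1 gives 116000 nM. Compound 2 `Fc1ccc(-c2nc3cnc(Nc4ccc(C(F)(F)F)cn4)cc3[nH]2)cc1F` gives 6000 nM in this assay. For compound 3 `Fc1ccc(-c2nc3cnc(Nc4cc(C(F)(F)F)ccn4)cc3[nH]2)cc1F` this assay reports < 5000 nM, which is a limit of the assay and not a number. Of the two numbers, compound 1 holds the higher one, and the nearest, compound 2, sits a good way lower, beyond the scatter. Compound 4 `NC(=O)c1ccc(Nc2cc3[nH]c(-c4cccc(C(F)(F)F)c4)nc3cn2)nc1` has not yet been measured. It differs from compound 1 in one place (5-carbamoylpyridin-2-yl in place of 3-methoxypyridin-2-yl on a nitrogen on an aromatic ring). Going by the values given here, no measured pair shows exactly this change, so the step is estimated rather than known: a moderate downward step, a 3.9-fold lower number from compound 1 to compound 4 (0.59 log units; beyond the scatter), is expected. Compound 4 is therefore expected near 30000 nM, with a likely range from 8000 nM to 100000 nM.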

Compound 4, solubility: < 5000 nM
Compound 4: a limit, no number; the forecaster's own chance of this, stated with the estimate: 10%; middle value at least 6.0-fold (0.77 log units) away from the limit.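

In this assay compound 4 gives < 5000 nM, which is a limit of the assay and not a number. Going by these compounds alone, replacing 3-methoxypyridin-2-yl with 5-carbamoylpyridin-2-yl still gives an at least 23-fold lower number from compound 1 to compound 4 (1.36 log units; beyond the scatter), the first evidence that a change at this place can carry a large step. The full size of the step cannot be read because the assay stops at a limit: the limit of < 5000 nM in this assay, at which 2 of the 4 values shown sit.

Open, from the compounds shown here alone, is whether the carbamoyl group itself or the loss of the methoxy group accounts for the step. A carboxylic acid or an amine in place of the carbamoyl group could help separate the two.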